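The compounds below may be only part of what the source reports. "The series", "measured", "known", "first", "only" and "open" are said of these compounds alone.

Measured compounds:
- Compound 1, `Cc1ccc(N2CCN(S(=O)(=O)C[C@]34CC[C@H](CC3=O)C4(C)C)CC2)nc1`. In a functional assay on CHO-K1 cells for antagonist activity at C-X-C chemokine receptor type 3 (Homo sapiens), read by FLIPR and calcium flux (a lower number here means a stronger inhibitor, a higher number a weaker inhibitor), compound 1 gives > 31600 nM, which is a limit of the assay rather than a number.
- Compound 2, `CC1(C)[C@@H]2CC[C@@]1(CS(=O)(=O)N1CCN(c3ccc(C(F)(F)F)cn3)CC1)C(O)C2`. In this assay compound 2 gives 158 nM.

Compound 2 stands on the only actual number shown here: the other result is a limit. Within the data shown here, the result for compound 1 is the limit of > 31600 nM in this assay, at which 1 of the 2 values shown sits, so the two values show only that compound 2 is measurable where compound 1 is not, and no step between them is given.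

Compound 3, `CC1(C)[C@@H]2CC[C@@]1(CS(=O)(=O)N1CCN(c3ccc(C(F)(F)F)cn3)CC1)C(F)C2`, is the next compound to be measured. It differs from compound 2 in one place: fluoro in place of hydroxy on a saturated ring carbon. Among the measured compounds shown here, no measured pair in this set shows the same swap, so the size of the step in this assay cannot be read from the data. A modest weakening, somewhat beyond the usual scatter, is expected. Compound 3 is estimated at 400 nM, with a range from 100 nM to 2000 nM. The expected step is a 2.5-fold higher number from compound 2 to compound 3 (0.40 log units; beyond the scatter).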

Compound 3, half-maximal inhibitory concentration: 794 nM
The estimate for compound 3 lay 2.0-fold (0.30 log units) below the measured number; the range from low to high includes it.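

In this assay, among these compounds, fluoro in place of hydroxy on a saturated ring carbon gives a 5.0-fold higher number from compound 2 to compound 3 (0.70 log units; beyond the scatter) and so weakens inhibition, which shows that this position responds to the swap even though only one heavy atom changes. Among the compounds shown here, the change takes away the hydrogen-bond donor and acceptor counted for hydroxy and leaves compound 3 with a real measured number rather than a limit, so this is the only step in the set whose size can be read. The numbers show how large the step is but give no measured reason for it, and nothing shown here explains why this swap moves the result by this amount.

The compounds shown leave open whether a plain hydrogen, a methoxy group, an amine or a carboxylic acid on this same ring carbon would keep the number of compound 2 or move it further in either direction. A single pair also cannot say whether the same swap would give a step of similar size on another compound.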